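The source may report more compounds than this note shows. Statements on the series, on what has been measured and on what is new or still open speak of the compounds shown alone.

Compound 1 `CC(=O)N(C)C(C)C#CCn1ccnc1` carries an acetyl group on its nitrogen. In a functional assay on the whole organism for antagonist activity, with Mus musculus as the target (a lower number here means that less compound is needed, a higher number that more compound is needed for the effect), compound 1 reaches only a limit, > 100 mg/kg, so no number is known for it; this is the limit of > 100 mg/kg in this assay, at which 1 of the 3 values shown sits. Compound 2 `CC(=O)N(C)C(C)C#CCn1ccnc1C` gives 0.2 mg/kg in this assay, and the change from compound 1, (methyl in place of hydrogen on an aromatic carbon), made an at least 500-fold lower number from compound 1 to compound 2 (2.69 log units; beyond the scatter). Compound 3 `CCOC(=O)N(C)C(C)C#CCn1ccnc1` gives 66 mg/kg; its core differs from that of compound 1 by ethoxy in place of methyl on a carbonyl carbon, a step of an at least 1.5-fold lower number from compound 1 to compound 3 (0.18 log units; that floor lies within the scatter). Compound 4 `CCOC(=O)N(C)C(C)C#CCn1cncc1C` is not yet measured. It differs from compound 3 by methyl in place of hydrogen on an aromatic carbon, the same kind of change as that from compound 1 to compound 2, but here the methyl sits next to the ring nitrogen and two ring bonds from the ring nitrogen, not between two ring nitrogen atoms. Resting on an at least 500-fold lower number from compound 1 to compound 2 (2.69 log units; beyond the scatter) at a different place, the step expected is an 11-fold lower number from compound 3 to compound 4 (1.04 log units; beyond the scatter). Compound 4 is estimated at 6 mg/kg, expected between 0.5 mg/kg and 66 mg/kg.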

Compound 4, dose for half-maximal effect: 17.3 mg/kg
The estimate for compound 4 lay 2.9-fold (0.46 log units) below the measured number; low and high end bracket the measured number.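

In this assay, methyl in place of hydrogen on an aromatic carbon gives a 3.8-fold lower number from compound 3 to compound 4 (0.58 log units; beyond the scatter), so the direction of the earlier step carries over to this core, but its size does not: the same change on two cores in this assay, an at least 500-fold lower number (2.69 log units; beyond the scatter) from compound 1 to compound 2 and a 3.8-fold lower number (0.58 log units; beyond the scatter) from compound 3 to compound 4, at least 130-fold (2.11 log units) apart, beyond the scatter of two such steps

The value of compound 1, > 100 mg/kg, is a limit and not a number. The two steps differ both in the group on the carbonyl carbon and in the ring place of the methyl, so these compounds cannot show which of the two sets the gap.

Still open, as far as these compounds go, is what the methyl does on the core of compound 3 at the ring place it holds in compound 2. Also open, from the compounds shown here alone, is how an ethyl group or an amine would fare at either ring place.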